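Swapping the Ring Nitrogen Substituent of Compound 1

This account rests on a few compounds, and the source may have more. Where it says the series, first, only, none or still open, it means among the compounds named here.

Compound 1 `CC(C)(C)OC(=O)N1CCC(O[C@H]2CC[C@H](Oc3cnc(S(C)(=O)=O)cn3)CC2)CC1` gives 64 nM in a functional assay on isolated protein for agonist activity at Glucose-dependent insulinotropic receptor (Rattus norvegicus), read by HTRF and cAMP accumulation (on this read-out higher numbers stand for an effect only at larger amounts of compound and lower numbers for an effect already at smaller amounts), the highest of the three numbers measured. Compound 2 `CC(C)S(=O)(=O)c1cnc(O[C@H]2CC[C@H](OC3CCN(C(=O)OC(C)(C)C)CC3)CC2)cn1` gives 54 nM and compound 3 `CC(C)(C)OC(=O)N1CCC(O[C@H]2CC[C@H](Oc3cnc(C#N)cn3)CC2)CC1` gives 28.4 nM; the steps are a 1.2-fold lower number from compound 1 to compound 2 (0.07 log units; within the scatter) and a 2.3-fold lower number from compound 1 to compound 3 (0.35 log units; beyond the scatter), with a 1.9-fold lower number from compound 2 to compound 3 (0.28 log units; within the scatter) between the latter two. All three steps alter the group on the aromatic carbon; none touches the amine nitrogen in a ring. Compound 4 `CS(=O)(=O)c1cnc(O[C@H]2CC[C@H](OC3CCN(CC4(C(F)(F)F)CCC4)CC3)CC2)cn1` differs from compound 1 exactly there: (1-(trifluoromethyl)cyclobutyl)methyl in place of tert-butoxycarbonyl on an amine nitrogen in a ring. Among the measured compounds shown here, no measured step bears on this change, so its size and direction cannot be read from the data; a step of modest size in either direction, or none beyond the scatter, is possible. For compound 4 the expected step is a 1.2-fold lower number from compound 1 to compound 4 (0.07 log units; within the scatter). Compound 4 is therefore estimated at 55 nM, ranging from 15 nM to 220 nM.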

Compound 4, half-maximal effective concentration: 80 nM
For compound 4 the middle estimate is 1.5-fold (0.16 log units) below the measured one, within the range that was stated.
By their numbers in this assay, from the lowest: compounds 3, 2, 1 and 4 (each within the scatter of the next, the first and the last beyond it).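

On the amine nitrogen in a ring, (1-(trifluoromethyl)cyclobutyl)methyl in place of tert-butoxycarbonyl gives a 1.3-fold higher number from compound 1 to compound 4 (0.10 log units; within the scatter) in this assay, so this first change at the position produces no step beyond the scatter. The entering group has no hydrogen-bond acceptors and the leaving group has two, yet the numbers stay within the scatter of each other. No evidence shown accounts for this result. Still open, as far as these compounds go, is how a free amine or a methyl group on this nitrogen would read, and whether cyano on the aromatic carbon would give a similar number alongside the new group.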